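Methoxy Added to a Triazole Scaffold Against HeLa Proliferation

A few compounds are considered here, and "the series" means these few. Any claim that something is new, unique, unknown or untested is made for them only; others in the source may bear on it.

Compound 1 `COc1cccc(-c2ncnn2-c2cc(OC)c(OC)c(OC)c2)c1`: > 10000 nM
Compound 2 `COc1cc(-c2ncnn2-c2ccccc2)cc(OC)c1OC`: > 10000 nM
Compound 3 `COc1cc(-n2ncnc2-c2ccccc2)cc(OC)c1OC`: > 10000 nM

In a functional assay on HeLa cells (Homo sapiens) for antiproliferative activity, read by MTT assay, with a stated time of 72 h (a lower number here means a stronger inhibitor, a higher number a weaker inhibitor), compound 1 gives > 10000 nM, a limit of the assay rather than a number. Compound 2 gives > 10000 nM in this assay, again a limit. Compound 3 likewise reaches only a limit, > 10000 nM. All three values sit at the limit of > 10000 nM in this assay, at which 3 of the 3 values shown sit. Compound 1 differs from compound 3 by methoxy in place of hydrogen on an aromatic carbon, and the step that the two limits leave unreadable from compound 3 to compound 1 is left unreadable by the two limits. The difference between the cores of compound 2 and compound 3 is not broken down here.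

Compound 4 `COc1ccc(-n2ncnc2-c2cc(OC)c(OC)c(OC)c2)cc1` differs from compound 2 by methoxy in place of hydrogen on an aromatic carbon. This is the same kind of change as from compound 3 to compound 1, but here the methoxy sits para to a large group rather than meta to it. A step that the limit leaves unreadable from compound 2 to compound 4 is expected. This rests on compound 1, whose value > 10000 nM is a limit after the same kind of change. Compound 4 is expected near 15000 nM in this assay, within 5000 nM to 50000 nM, most likely again only a limit.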

Compound 4, half-maximal inhibitory concentration: > 10000 nM
Compound 4: a limit, no number; the forecaster's own chance of this, stated with the estimate: 80%; the middle value is on the limit's open side.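

Compound 2 and compound 4 both stand at a limit rather than a number, so no step between them can be read: the limit of > 10000 nM in this assay, at which 4 of the 4 values shown sit.

The compounds shown leave open whether methoxy in place of hydrogen changes activity at all in this assay here.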